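Replacing ethoxy with phenyl on the diaryl ether

A few compounds are considered here, and "the series" means these few. Any claim that something is new, unique, unknown or untested is made for them only; others in the source may bear on it.

Compound 3 `CCOc1ccccc1Oc1ccc(N2CCC[C@H]2CC(=O)O)cc1` stands at the high end of the three compounds measured: in a functional assay on cells for agonist activity at Free fatty acid receptor 1 (Homo sapiens), read by FLIPR and calcium flux, with a stated time of 100 s (a higher number here means that more compound is needed for the effect, a lower number that less compound is needed), compound 3 gives 1700 nM, whereas compound 1 `O=C(O)C[C@@H]1CCCN1c1ccc(Oc2ccccc2)cc1` gives 560 nM and compound 2 `O=C(O)C[C@@H]1CCCN1c1ccc(Oc2ccccc2F)cc1` gives 150 nM. Both steps that lead to compound 3 raised the number, a 3.0-fold higher number from compound 1 to compound 3 (0.48 log units; beyond the scatter) and an 11-fold higher number from compound 2 to compound 3 (1.05 log units; beyond the scatter), while a 3.7-fold lower number from compound 1 to compound 2 (0.57 log units; beyond the scatter) lowered it. Compound 4 `O=C(O)C[C@@H]1CCCN1c1ccc(Oc2ccccc2-c2ccccc2)cc1` differs from compound 3 by phenyl in place of ethoxy on an aromatic carbon, on an aromatic carbon ortho to a large group. Going by the values given here, no measured step puts a phenyl on that aromatic carbon, so the expectation rests only on the observation that the ethoxy of compound 3 went with the highest number of the set, as a 3.0-fold higher number from compound 1 to compound 3 (0.48 log units; beyond the scatter) shows. Going by these compounds, removing that ethoxy is expected to leave the number no higher and possibly somewhat lower, but the phenyl itself is untested, so the range is wide. For compound 4 the estimate in this assay is 900 nM, between 250 nM and 3500 nM. This corresponds to an expected step of a 1.9-fold lower number from compound 3 to compound 4 (0.28 log units; within the scatter).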

Compound 4, half-maximal effective concentration: 3500 nM
For compound 4 the middle estimate is 3.9-fold (0.59 log units) below the measured one, within the range that was stated.
By their numbers in this assay, from the lowest: compound 2; then compound 1; then compound 3; then compound 4.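

On this aromatic carbon, ortho to a large group, removing ethoxy did not lower the number: phenyl in its place gave a 2.1-fold higher number from compound 3 to compound 4 (0.31 log units; beyond the scatter) in this assay, so the ethoxy of compound 3 was not alone in raising it. Measured against hydrogen, phenyl gave a 6.3-fold higher number from compound 1 to compound 4 (0.80 log units; beyond the scatter), and against fluoro it gave a 23-fold higher number from compound 2 to compound 4 (1.37 log units; beyond the scatter), the widest step in the set, so two of the three groups placed here raise the number over hydrogen, with the fluoro of compound 2 going against that trend. No measured evidence on the compounds accounts for these steps.

The compounds shown leave open whether chloro or methoxy at this carbon would follow fluoro or ethoxy. They also leave open whether a pyridine ring in place of the phenyl would give a lower number than compound 4 does.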